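The source may report more compounds than this note shows. Statements on the series, on what has been measured and on what is new or still open speak of the compounds shown alone.

Measured so far in a functional assay on HEK293 cells for agonist activity at Neuronal acetylcholine receptor; alpha4/beta2 (Homo sapiens), read by FLIPR and calcium flux; on this read-out lower numbers stand for an effect already at smaller amounts and higher numbers for an effect only at larger amounts of compound:
compound 1 `Brc1ccc(N2CCCNCCC2)cn1` gives 1.29 nM;
compound 2 `c1cncc(N2CCCNCCC2)c1` gives 36.3 nM;
compound 3 `COc1ccc(N2CCCNCC2)cn1` gives 11000 nM.

Compound 2 stands second highest of the three numbers. Its nearest neighbour is compound 1, which gives a lower number, and its furthest is compound 3, which gives a much higher number; compound 3 also carries a different core, so its value is noted only as the far end of the range.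

Compound 4 `Brc1cncc(N2CCCNCCC2)c1` has not yet been measured. It differs from compound 2 in one place: bromo in place of hydrogen on an aromatic carbon.

Going by the values given here, one measured step bears on this change. Going a 28-fold higher number from compound 1 to compound 2 (1.45 log units; beyond the scatter), the loss of a bromo from the core raised the number sharply. Among the compounds with values here, compound 4 puts a bromo back onto the core, so the step seen there is read in reverse, but whether the gain carries over to this place on the ring is uncertain, as no measured pair tests it.

On this basis a moderate step downward is expected, a 3.6-fold lower number from compound 2 to compound 4 (0.56 log units; beyond the scatter), and compound 4 is estimated at 10 nM, with a range from 2 nM to 60 nM.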

Compound 4, half-maximal effective concentration: 182 nM
The estimate for compound 4 lay 18-fold (1.26 log units) below the measured number, outside the stated range (above it).
By their numbers in this assay, from the lowest: compound 1; then compound 2; then compound 4; then compound 3.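

In this assay, bromo in place of hydrogen on an aromatic carbon two atoms from the ring nitrogen, meta to a group of 8 heavy atoms, gives a 5.0-fold higher number from compound 2 to compound 4 (0.70 log units; beyond the scatter) and so moves the number upward. Set against a 28-fold higher number from compound 1 to compound 2 (1.45 log units; beyond the scatter), where losing the bromo also raised the number, this shows that on the shared core a bromo does not act the same way at every place: at this place it costs activity, while in compound 1 its presence goes with the lower number. Nothing measured here accounts for this difference between the two places.

On these data alone, it remains open whether an amine, a nitrile or a chloro at this same place would move the number as bromo does. Also open, as far as these compounds go, is whether the rise seen here would hold on a different core.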